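A Third Methoxy Group and Its Expected Cytotoxicity

This account rests on a few compounds, and the source may have more. Where it says the series, first, only, none or still open, it means among the compounds named here.

Compound 1 `Cc1ncc([N+](=O)[O-])n1CCSc1nnc(-c2ccccc2)o1` was tested in a functional assay on HepG2 cells (Homo sapiens) for cytotoxicity, read by MTT assay, with a stated time of 48 h (a lower number here means a stronger inhibitor, a higher number a weaker inhibitor), where compound 1 gives 17500 nM. Compound 2 `COc1ccccc1-c1nnc(SCCn2c([N+](=O)[O-])cnc2C)o1` carries methoxy in place of hydrogen on an aromatic carbon, and in this assay compound 2 gives 10000 nM; the step is a 1.8-fold lower number from compound 1 to compound 2 (0.24 log units; within the scatter). Compound 3 `COc1cc(OC)cc(-c2nnc(SCCn3c([N+](=O)[O-])cnc3C)o2)c1` differs from compound 1 in more than one place, and the difference between the two cores is not broken down here; in this assay compound 3 gives 10500 nM, which sits close to compound 2. Compound 4 `COc1cc(-c2nnc(SCCn3c([N+](=O)[O-])cnc3C)o2)cc(OC)c1OC` has not yet been measured. It differs from compound 3 by methoxy in place of hydrogen on an aromatic carbon, the same kind of change as that from compound 1 to compound 2, though the surroundings differ: in compound 2 the new group sits ortho to a large group, whereas in compound 4 it sits ortho to two methoxy groups and para to a large group. Because the earlier step of a 1.8-fold lower number from compound 1 to compound 2 (0.24 log units; within the scatter) stayed within the scatter, the step of a 1.2-fold lower number from compound 3 to compound 4 (0.07 log units; within the scatter) is expected to be small as well. Compound 4 is estimated at 9000 nM in this assay, with a likely range from 4000 nM to 22000 nM.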

Compound 4, half-maximal inhibitory concentration: 14900 nM
Compound 4: the middle estimate sits 1.7-fold (0.22 log units) below what was measured; measured number inside the range.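

In this assay, methoxy in place of hydrogen on an aromatic carbon gives a 1.4-fold higher number from compound 3 to compound 4 (0.15 log units; within the scatter) and so leaves the number within the scatter on this core too. Set beside the earlier step, the two cores cannot be told apart for this change: the same change on two cores in this assay, a 1.8-fold lower number (0.24 log units; within the scatter) from compound 1 to compound 2 and a 1.4-fold higher number (0.15 log units; within the scatter) from compound 3 to compound 4, 2.5-fold (0.40 log units) apart, within the scatter of two such steps. This shows that in these two pairs the change carries over without a step that stands clear of the scatter, even though its place differs on the second core, where it sits ortho to two methoxy groups and para to a large group; it does not show that the two steps truly run in opposite directions, nor that methoxy would behave the same way on any other core.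

Every compound shown carries only hydrogen or methoxy on the six-membered aromatic ring, so what an amine or a carboxylic acid in that place would do remains open. Also open, as far as these compounds go, is whether a longer chain in place of methoxy would move the number beyond the scatter in this assay at all.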